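The source may report more compounds than this note shows. Statements on the series, on what has been measured and on what is new or still open speak of the compounds shown alone.

Compound 1 `COc1cc(/C=C2\CN(C)C/C(=C\c3ccc(Cl)cc3Cl)C2=O)cc(OC)c1` gives 6250 nM
Compound 2 `COc1cc(/C=C2\CN(C)C/C(=C\c3cc(OC)c(OC)c(OC)c3)C2=O)cc(OC)c1` gives 890 nM
Compound 3 `CN1C/C(=C\c2ccc(F)cc2)C(=O)/C(=C/c2ccc(C#N)cc2)C1` gives 6140 nM

In a functional assay on HepG2 cells (Homo sapiens) for cytotoxicity, read by MTT assay, with a stated time of 24 h (on this read-out higher numbers stand for weaker inhibition and lower numbers for stronger inhibition), compound 3 (6140 nM) sits level with compound 1 within the scatter, while compound 2 (890 nM) lies lower, beyond the scatter. Compound 4 `CN1C/C(=C\c2ccc(C#N)cc2)C(=O)/C(=C/c2ccc(Cl)cc2Cl)C1` has 2,4-dichlorophenyl in place of 4-fluorophenyl on a double-bonded chain carbon bound to a double-bonded ring carbon. Among the measured compounds shown here, no measured pair isolates this change. Compound 1 (6250 nM) also carries 2,4-dichlorophenyl and stands level with compound 3, so no step beyond the scatter is expected in this assay for this change. The expected shift is small (a 1.2-fold lower number from compound 3 to compound 4 (0.09 log units; within the scatter)). For compound 4 the estimate is 5000 nM with an expected range of 2000 nM to 12000 nM when it is measured.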

Compound 4, half-maximal inhibitory concentration: 6250 nM
For compound 4 the middle estimate is 1.3-fold (0.10 log units) below the measured one; the measured number falls inside the stated range.
By their numbers in this assay, from the lowest: compound 2; then compounds 3, 1 and 4 (each within the scatter of the next).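

In this assay, replacing 4-fluorophenyl with 2,4-dichlorophenyl on a double-bonded chain carbon bound to a double-bonded ring carbon gives a 1.0-fold higher number from compound 3 to compound 4 (0.01 log units; within the scatter) with the rest of the molecule unchanged. Among the compounds shown here, this is the first comparison here that isolates a single place, and at this place the two groups cannot be told apart on this read-out. Nothing measured here bears on why the exchange leaves the number level. The compounds shown leave open whether an amine or a carboxylic acid on the phenyl ring at this place would also leave the number level. They also leave open whether the same exchange would stay within the scatter with a different group at the other double-bonded chain carbon.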